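The source may report more compounds than this note shows. Statements on the series, on what has been measured and on what is new or still open speak of the compounds shown alone.

In an ADME assay on Huh-7 cells (Homo sapiens) for cytotoxicity, read by XTT assay (on this read-out lower numbers stand for higher toxicity in this test and higher numbers for lower toxicity in this test), compound 1 `OC[C@H]1C[C@@H](n2cnc3c(Cl)ncnc32)[C@@H]1CO` gives > 200000 nM, which is a limit of the assay. Compound 2 `CCCC(=O)OC[C@H]1O[C@@H](n2cnc3c(Cl)ncnc32)C[C@@H]1O` gives > 200000 nM, also only a limit. Compound 2 thus stands at the limit of > 200000 nM in this assay, at which 2 of the 3 values shown sit. Compound 3 `Cc1cc(C)c(C(=O)OC[C@H]2O[C@@H](n3cnc4c(Cl)ncnc43)C[C@@H]2O)c(C)c1` gives a true number, 91000 nM. Compound 4 `C=CCOC[C@H]1O[C@@H](n2cnc3c(Cl)ncnc32)C[C@@H]1O` differs from compound 2 as follows: allyl in place of propylcarbonyl on an oxygen on a saturated carbon. Allyl thus takes the place of propylcarbonyl on an oxygen on a saturated carbon. For the measured compounds named here, only one measured step bears on this, an at least 2.1-fold lower number from compound 2 to compound 3 (0.34 log units; beyond the scatter), and it is modest and keeps the carbonyl. A small move toward lower numbers in this assay is therefore expected, with the limit still possible, and the estimated step is an at least 1.1-fold lower number from compound 2 to compound 4 (0.07 log units; that floor lies within the scatter). For compound 4 the expected value is 170000 nM, with an estimated range of 80000 nM to 350000 nM.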

Compound 4, half-maximal cytotoxic concentration: 140000 nM
Beside the measured number, compound 4's estimate is 1.2-fold (0.08 log units) above it, and the stated range covers the measured number.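

In this assay, allyl in place of propylcarbonyl on an oxygen on a saturated carbon gives an at least 1.4-fold lower number from compound 2 to compound 4 (0.15 log units; that floor lies within the scatter). Compound 4 has no carbonyl at this place, yet like compound 3 it gives a true number, so an ester carbonyl is not required there for a value inside the assay's range. The true size of the step stays open, since compound 2 is only a limit: the limit of > 200000 nM in this assay, at which 2 of the 4 values shown sit.

The compounds shown leave open whether a saturated propyl ether, an amine or a carboxylic acid on this oxygen would also give a true number.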